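The compounds below may be only part of what the source reports. "The series", "measured", "known", "first", "only" and "open" are said of these compounds alone.

Measured so far in an assay on HEK293 cells for inhibition of N-acylethanolamine-hydrolyzing acid amidase (Rattus norvegicus), read by LC-MS, with a stated time of 30 min; a higher number here means a weaker inhibitor, a lower number a stronger inhibitor: compound 1 `O=C(CCCCCCc1ccc(O)cc1)N1CCCC1` gives 5600 nM; compound 2 `COc1ccc(CCCCCCC(=O)N2CCCC2)cc1` gives 35400 nM.

Within the data shown here, compound 2 stands at the higher of the two numbers, and its only neighbour is compound 1, which sits a step lower: a 6.3-fold higher number from compound 1 to compound 2 (0.80 log units; beyond the scatter). That step is the whole of what has been measured, and it came from methyl in place of hydrogen on an oxygen on an aromatic ring.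

Compound 3 `O=C(O)c1ccc(CCCCCCC(=O)N2CCCC2)cc1` differs from compound 2 at that same aromatic carbon: carboxy in place of methoxy on an aromatic carbon. Among the measured compounds shown here, the one measured step bears on this only loosely. Putting methyl in place of the hydrogen on the oxygen raised the number in this assay by a modest amount, and compound 3 brings a hydrogen-bond donor back, but within a carboxy group rather than as a hydrogen on an oxygen on an aromatic ring, and nothing measured shows how a carboxy group behaves here. For the measured compounds named here, with no closer precedent, the step is estimated as a 1.8-fold lower number from compound 2 to compound 3 (0.25 log units; within the scatter). Compound 3 is therefore expected to give 20000 nM, with a wide range from 4000 nM to 100000 nM.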

Compound 3, half-maximal inhibitory concentration: > 100000 nM
Compound 3: a limit, no number (the forecaster's own chance of this, stated with the estimate: 25%); middle value at least 5.0-fold (0.69 log units) away from the limit.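

this assay gives compound 3 a limit rather than a number, so its true value cannot be read and its steps are minimum sizes only: the limit of > 100000 nM in this assay, at which 1 of the 3 values shown sits.

Even so, the change of group has a clear direction: carboxy in place of methoxy gives an at least 2.8-fold higher number from compound 2 to compound 3 (0.45 log units; beyond the scatter), and carboxy in place of hydroxy gives an at least 17-fold higher number from compound 1 to compound 3 (1.25 log units; beyond the scatter). Carboxy carries a hydrogen-bond donor where methoxy carries none, yet the number still rises, so adding a donor at this aromatic carbon is not enough on its own to make a stronger inhibitor; that could not be seen from the single earlier step. Among the three groups shown at this carbon, hydroxy gives the lowest number, and moving to either methoxy or carboxy gives a weaker inhibitor.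

On these data alone, how far compound 3 lies past the limit remains unknown, as does whether its weakness comes from the carboxy group as a whole or from one part of it. A methyl ester or a primary amide at the same carbon would help separate those possibilities, while an amine there would test a different kind of group.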